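Anilino substituent exchange on the shared core

The source may report more compounds than this note shows. Statements on the series, on what has been measured and on what is new or still open speak of the compounds shown alone.

Compound 1 `C#CCSc1nc(Nc2ccc(Cl)cc2)c(C#N)c(-c2ccccc2)n1` and compound 2 `N#Cc1c(Nc2ccccc2Cl)nc(SCc2cn(Cc3ccccc3Cl)nn2)nc1-c1ccccc1` share a core and differ at two positions. In a functional assay on MCF7 cells (Homo sapiens) for inhibition, read by MTT assay, with a stated time of 72 h (on this read-out lower numbers stand for stronger inhibition and higher numbers for weaker inhibition), compound 1 gives only a limit, > 128000 nM, which is the point at which (the limit of > 128000 nM in this assay, at which 1 of the 2 values shown sits). In this assay, among the measured compounds shown here, compound 2 gives 1950 nM, the only numerical value in the set, and so the sole measured point against which compound 3 can be set. Compound 3 `Cc1ccc(Nc2nc(SCc3cn(Cc4ccccc4Cl)nn3)nc(-c3ccccc3)c2C#N)cc1` differs from compound 2 in one place: 4-methylphenyl in place of 2-chlorophenyl on a nitrogen on an aromatic ring. For the measured compounds named here, no pair of measured compounds differs in a single place, so no measured step bears directly on this change; both entering and leaving groups carry no donors or acceptors and the count of heavy atoms is unchanged. The expected step is a 1.3-fold higher number from compound 2 to compound 3 (0.11 log units; within the scatter), not clearly beyond the scatter in either direction. Compound 3 is estimated at 2500 nM in this assay, within a range from 800 nM to 8000 nM.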

Compound 3, half-maximal inhibitory concentration: 9420 nM
Beside the measured number, compound 3's estimate is 3.8-fold (0.58 log units) below it; the whole stated range lies below it.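

Compounds 1 and 2 differ at two positions, so they gave no reading of any single change, whereas in this assay the exchange of 2-chlorophenyl for 4-methylphenyl on the nitrogen gives a 4.8-fold higher number from compound 2 to compound 3 (0.68 log units; beyond the scatter). This position therefore responds to the aryl group it carries, even though both groups have the same count of heavy atoms and neither has hydrogen-bond donors or acceptors. Nothing shown here gives a cause for this step.

Among the compounds shown here, the single pair changes the identity of the substituent and its numbered place on the ring together, so the contribution of each stays unresolved. Results for 2-methylphenyl or 4-methoxyphenyl on the same nitrogen, with the remainder of compound 2 unchanged, would be needed to separate them.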